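A few compounds are considered here, and "the series" means these few. Any claim that something is new, unique, unknown or untested is made for them only; others in the source may bear on it.

Compound 1 `CCCCOc1ccccc1Cc1cnc(N)nc1N` gives 8710 nM in an assay for inhibition of Dihydrofolate reductase (Gallus gallus) (a higher number here means a weaker inhibitor, a lower number a stronger inhibitor), the lowest of the three numbers at hand. Compound 2 `CS(=O)(=O)Oc1ccccc1Cc1cnc(N)nc1N` gives 22900 nM, and compound 3 `NC(=O)COc1ccccc1Cc1cnc(N)nc1N` gives 33900 nM. Compound 4 `Nc1ncc(Cc2ccccc2F)c(N)n1` differs from compound 1 by fluoro in place of butoxy on an aromatic carbon. The two measured steps from compound 1 alter the group on that same oxygen: a 2.6-fold higher number from compound 1 to compound 2 (0.42 log units; beyond the scatter) and a 3.9-fold higher number from compound 1 to compound 3 (0.59 log units; beyond the scatter), both modest rises. Neither step removes the oxygen, so they bear on the new change only loosely, yet both point upward. Compound 4 is therefore expected to show a rise of comparable or somewhat larger size, an estimated step of a 2.9-fold higher number from compound 1 to compound 4 (0.46 log units; beyond the scatter). Compound 4 is estimated at 25000 nM in this assay, within a range from 7000 nM to 90000 nM.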

Compound 4, inhibition constant: 43700 nM
Beside the measured number, compound 4's estimate is 1.7-fold (0.24 log units) below it, and the stated range covers the measured number.
By their numbers in this assay, from the lowest: compound 1; then compounds 2, 3 and 4 (each within the scatter of the next).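

In this assay, fluoro in place of butoxy removes the oxygen as well as the chain, yet a 5.0-fold higher number from compound 1 to compound 4 (0.70 log units; beyond the scatter) still separates the two compounds. Compound 4 cannot be told apart from the other two analogues, with a 1.3-fold higher number from compound 3 to compound 4 (0.11 log units; within the scatter) and a 1.9-fold higher number from compound 2 to compound 4 (0.28 log units; within the scatter) both within the scatter, so among these four only compound 1, with its butoxy, stands apart at this position. Nothing at hand gives a reason for this. As far as these compounds go, whether the lower number depends on the full butyl chain remains open. A methoxy, a hydroxy or a longer chain such as hexyloxy could show this.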